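Indole nitrogen substitution on a pyridyl isoxazoline series

This account rests on a few compounds, and the source may have more. Where it says the series, first, only, none or still open, it means among the compounds named here.

Measured compounds:
compound 1, `COc1ccc2c(c1)c(C1CC(c3ccncc3)=NO1)cn2Cc1ccc(Cl)cc1`: > 100000 nM
compound 2, `COc1ccc2c(C3CC(c4ccncc4)=NO3)c[nH]c2c1`: 9500 nM
compound 3, `COc1ccc2[nH]cc(C3CC(c4ccncc4)=NO3)c2c1`: 68500 nM

Three compounds sharing a pyridyl isoxazoline arm on a methoxy-substituted bicyclic core have been tested in a functional assay on BXPC-3 cells (Homo sapiens) for inhibition, read by MTT assay, with a stated time of 48 h; a higher number here means a weaker inhibitor, a lower number a stronger inhibitor. Compound 2 gives 9500 nM there. Compound 3 gives 68500 nM in this assay, a higher number than compound 2 by a margin beyond the scatter. The difference between the cores of compound 2 and compound 3 is not broken down here. For compound 1 this assay reports only a limit, > 100000 nM, and not a number.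

Compound 1 is derived from compound 3 by one change, (4-chlorobenzyl in place of hydrogen on an aromatic nitrogen). This produced an at least 1.4-fold higher number from compound 3 to compound 1 (0.16 log units; that floor lies within the scatter), and the step is bounded only because of the limit of > 100000 nM in this assay, at which 1 of the 3 values shown sits.

The unmeasured compound 4, `COc1ccc2c(C3CC(c4ccncc4)=NO3)cn(Cc3ccc(Cl)cc3)c2c1`, stands to compound 2 as compound 1 stands to compound 3: the change is 4-chlorobenzyl in place of hydrogen on an aromatic nitrogen, the same change in the same place. Since compound 1 returns only a limit where compound 3 returns a number, the same change on compound 2 is expected to raise the number, with the true size of the first step unknown beyond its floor. The account therefore expects from compound 2 to compound 4 a step of a 4.2-fold higher number from compound 2 to compound 4 (0.62 log units; beyond the scatter). Compound 4 is thus estimated at 40000 nM in this assay, with a range from 12000 nM to 100000 nM, and a real chance that only a limit is returned.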

Compound 4, half-maximal inhibitory concentration: > 100000 nM
Compound 4: only a limit was reported (the forecaster's own chance of this, stated with the estimate: 30%); middle value at least 2.5-fold (0.39 log units) from the limit.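

In this assay compound 4 returns only a limit, > 100000 nM, and not a number. The change of 4-chlorobenzyl in place of hydrogen on an aromatic nitrogen therefore gives an at least 10-fold higher number from compound 2 to compound 4 (1.02 log units; beyond the scatter), so on this core the loss is large even at its floor, and the two cores agree in direction, though only as far as their floors allow, one of which lies within the scatter: the same change on two cores in this assay, an at least 1.4-fold higher number (0.16 log units; that floor lies within the scatter) from compound 3 to compound 1 and an at least 10-fold higher number (1.02 log units; beyond the scatter) from compound 2 to compound 4; the limit leaves it open whether they differ. What this does not show is the true size of the step on either core, or whether one core is more sensitive to the change than the other, since both substituted compounds report only the same ceiling: the limit of > 100000 nM in this assay, at which 2 of the 4 values shown sit.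

The compounds shown carry only hydrogen or 4-chlorobenzyl on that nitrogen, so it remains open whether a smaller group such as methyl, an unsubstituted benzyl, or a short chain ending in an amine or a carboxylic acid would keep a measurable number. Going by these compounds, it is also open whether the loss belongs to the 4-chlorobenzyl group as a whole or to the chlorine it carries, and whether a phenyl in place of the pyridyl ring of the shared arm would alter the picture on either core.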